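A few compounds are considered here, and "the series" means these few. Any claim that something is new, unique, unknown or untested is made for them only; others in the source may bear on it.

Compound 2 `C/C(=N\CCO)c1c(O)c2ccccc2[nH]c1=O` stands in an assay on isolated protein for inhibition of myosin-2 (Bos taurus), read by spectrophotometry, with a stated time of 24 min (on this read-out higher numbers stand for weaker inhibition and lower numbers for stronger inhibition), only at a limit: compound 2 gives >= 100000 nM, which is a limit of the assay and not a number. Compound 1 `C/C(=N\Cc1ccccc1)c1c(O)c2ccccc2[nH]c1=O` likewise gives >= 100000 nM, also a limit. Going by the values given here, the only measured step, a step that the two limits leave unreadable from compound 1 to compound 2, thus cannot be sized, as the limit of >= 100000 nM in this assay, at which 2 of the 2 values shown sit, shows. Compound 3 `C/C(=N\CC1CCCCC1)c1c(O)c2ccccc2[nH]c1=O` differs from compound 2 by cyclohexyl in place of hydroxymethyl on a saturated chain carbon bound to a double-bonded nitrogen. With both measured values at the limit, no direction can be read. The expected step of a number no higher from compound 2 to compound 3 (the limit leaves the size open) is therefore taken as none beyond the scatter. Compound 3 is expected at 100000 nM, in the range 30000 nM to 300000 nM, most likely again only a limit.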

Compound 3, half-maximal inhibitory concentration: >= 100000 nM
Compound 3: a limit, no number (the forecaster's own chance of this, stated with the estimate: 75%); the middle value lies on the limit itself.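

Going by these compounds alone, no step among compound 1, compound 2 and compound 3 can be read, as all three stand only at a limit and not at a number: the limit of >= 100000 nM in this assay, at which 3 of the 3 values shown sit. Which group on the saturated chain carbon, if any, would give a measurable value stays open.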